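A few compounds are considered here, and "the series" means these few. Any claim that something is new, unique, unknown or untested is made for them only; others in the source may bear on it.

In an ADME assay on a cell-free system (plasma, Mus musculus) for metabolic stability, tested at 1 uM (on this read-out higher numbers stand for a longer-lived compound and lower numbers for a shorter-lived compound), three compounds have readings so far. Compound 1 (`C=CC(=O)N1CCN(S(=O)(=O)c2ccc(NC(=O)OCc3ccccc3)cc2)CC1`) gives > 6 h here, which is a limit of the assay and not a number. Compound 2 (`C=CC(=O)NC1CN(S(=O)(=O)c2ccc(NC(=O)OCc3ccccc3)cc2)C1`) gives > 6 h here, again a limit. Compound 3 (`C=CC(=O)NC1CCN(S(=O)(=O)c2ccc(C(=O)NCCCc3ccccc3)cc2)CC1`), the starting point for this step, gives > 6 h as well, and this too is a limit, so no exact half-life is known for it.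

Compound 4 (`C=CC(=O)NC1CCN(S(=O)(=O)c2ccc(C(=O)NCc3cccc4ccccc34)cc2)CC1`) has not been measured yet. The structural change is naphthalen-1-yl in place of phenethyl on a saturated chain carbon bound to an amide-type nitrogen and, put simply, naphthalen-1-yl stands in place of phenethyl on a saturated chain carbon bound to an amide-type nitrogen.

Among the measured compounds shown here, the one measured step is a step that the two limits leave unreadable from compound 1 to compound 2 and it lies at a different place from this change, so it offers no size to carry over. What remains is a shared ceiling, and compound 4 is expected to stay near it because of the limit of > 6 h in this assay, at which 3 of the 3 values shown sit, rather than any step of known size. The step expected in this assay is a step that the limit leaves unreadable from compound 3 to compound 4 with no direction expected beyond the usual scatter. For compound 4 the estimated half-life is 8 h with an expected range from 4 h to 20 h and another limit is the likeliest report.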

Compound 4, half-life: > 6 h
Compound 4: a limit, no number; the forecaster's own chance of this, stated with the estimate: 85%; the middle value does not contradict the limit.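

Compound 3 and compound 4 each give only a limit in this assay and not a number, so no new step can be read between them, because both sit at the same ceiling: the limit of > 6 h in this assay, at which 4 of the 4 values shown sit. The compounds shown leave open how long any of them actually lasts, and whether naphthalen-1-yl in place of phenethyl alters that at all.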